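The source may report more compounds than this note shows. Statements on the series, on what has been measured and on what is new or still open speak of the compounds shown alone.

Compound 1 `CN(C)c1ccc(/C=C(/Sc2ccc(Br)cc2)C(=O)c2ccc(Cl)cc2)cc1`: in a functional assay on DU-145 cells (Homo sapiens) for inhibition, read by trypan blue exclusion, with a stated time of 96 h (on this read-out lower numbers stand for stronger inhibition of growth and higher numbers for weaker inhibition of growth), compound 1 gives > 100000 nM, a limit of the assay.
Compound 2 `Cc1ccc(CS/C(=C/c2ccc(N(C)C)cc2)C(=O)c2ccc(Cl)cc2)cc1`: in this assay compound 2 gives > 100000 nM, a limit of the assay.
Compound 3 `Cc1ccc(S/C(=C/c2ccc(N(C)C)cc2)C(=O)c2ccc(Cl)cc2)cc1`: in this assay compound 3 gives > 100000 nM, a limit of the assay.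

Compound 2 thus stands only at a limit in this assay, and the same holds for every value shown (the limit of > 100000 nM in this assay, at which 3 of the 3 values shown sit). The three measured steps, a step that the two limits leave unreadable from compound 1 to compound 2, a step that the two limits leave unreadable from compound 1 to compound 3 and a step that the two limits leave unreadable from compound 2 to compound 3, have no readable size. Compound 4 `Cc1ccc(CS/C(=C/c2ccc(O)cc2)C(=O)c2ccc(Cl)cc2)cc1` differs from compound 2 by hydroxy in place of dimethylamino on an aromatic carbon. For the measured compounds named here, none of the measured steps concerns this part of the structure, and none gives a direction, so the change carries no expectation beyond the scatter. Compound 4 is expected to give about 150000 nM, within 30000 nM to 600000 nM, in this assay. The expected step that the limit leaves unreadable from compound 2 to compound 4 is therefore estimated as small, and most likely compound 4 will again reach only a limit.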

Compound 4, concentration for 50% growth inhibition: 10000 nM
The estimate for compound 4 lay 15-fold (1.18 log units) above the measured number; the whole stated range lies above it.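

For the compounds shown here, on the 4-hydroxyphenyl in place of the 4-(dimethylamino)phenyl, this assay gives the first step of readable size: an at least 10-fold lower number from compound 2 to compound 4 (1.00 log units; beyond the scatter). Compound 2 stands at a limit, so this step fixes only a minimum size, while the steps among compounds 1, 2 and 3 cannot be read. Only compound 4 comes off the limit shared by the others: the limit of > 100000 nM in this assay, at which 3 of the 4 values shown sit.

On these data alone, whether hydroxy gives a similar step with the 4-methylphenyl on sulfur of compound 3 remains open. So does how a methoxy, a primary amine or a carboxylic acid would read at this position.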